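Replacing Fluoro with Chloro on a Nicotinic Receptor Ligand

The compounds below may be only part of what the source reports. "The series", "measured", "known", "first", "only" and "open" are said of these compounds alone.

Of the compounds shown here, two sharing one core have been tested in an assay on HEK293 cells for displacement of a labelled ligand from Neuronal acetylcholine receptor; alpha3/beta4 (Homo sapiens), read by radioligand binding, with a stated time of 5 min; on this read-out lower numbers stand for stronger inhibition and higher numbers for weaker inhibition. Compound 1, `Fc1cccc(C2=NCCCC2)c1`, carries a fluoro group on its aromatic ring; in this assay compound 1 gives 108 nM. Compound 2, `Brc1cc(Br)cc(C2=NCCCC2)c1`, carries two bromo groups instead, and in this assay compound 2 gives 70.8 nM. Compound 1 thus has the higher of the two numbers, but the gap to compound 2 is small and falls within the usual scatter, so the two values cannot be told apart with confidence.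

Among the compounds with values here, no pair of measured compounds differs in only one place, so no single measured step guides the next move. Compound 3, `Clc1cccc(C2=NCCCC2)c1`, differs from compound 1 by chloro in place of fluoro on an aromatic carbon, meta to a group of 6 heavy atoms. Within the data shown here, with no measured precedent for this swap, the expected step from compound 1 to compound 3 is modest, a 1.4-fold lower number from compound 1 to compound 3 (0.13 log units; within the scatter), leaning slightly toward a lower number but not clearly beyond the scatter. Compound 3 is therefore estimated at 80 nM, with a plausible range from 35 nM to 200 nM.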

Compound 3, inhibition constant: 77.2 nM
Estimate against measurement, compound 3: 1.0-fold (0.02 log units) above; the measured number falls inside the stated range.
By their numbers in this assay, from the lowest: compounds 2, 3 and 1 (each within the scatter of the next).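

Within the data shown here, this pair is the first to differ in one place only, so the swap of fluoro for chloro can now be read directly: in this assay, the change gives a 1.4-fold lower number from compound 1 to compound 3 (0.15 log units; within the scatter) and thus lies within the scatter. At this position on the aromatic carbon, meta to a group of 6 heavy atoms, the two halogens therefore cannot be told apart, and the larger step that might have been seen here does not appear. No supporting data bear on what lies behind this result.

This single step covers only two halogens, each a group of 1 heavy atom with 0 hydrogen-bond donors and 0 hydrogen-bond acceptors, and says nothing about how the number would respond to other kinds of group. An amine, a carboxylic acid or a longer chain at the same place would show whether this position stays as indifferent to change as the swap from fluoro to chloro suggests, or whether that apparent indifference holds only between these two halogens.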